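Swapping the amide-end group on a cholesterol-transporter binder

This account rests on a few compounds, and the source may have more. Where it says the series, first, only, none or still open, it means among the compounds named here.

Of the compounds shown here, three sharing one core have been measured in an assay on HEK293 cells for displacement of a labelled ligand from NPC1-like intracellular cholesterol transporter 1 (Homo sapiens); on this read-out lower numbers stand for stronger inhibition and higher numbers for weaker inhibition. Compound 1 `CCC1CCCN(C(=O)CN2CN(c3ccccc3)C3(CCN(C(=O)c4ccc(C5CCCCC5)cc4)CC3)C2=O)C1` gives 2600 nM, compound 2 `CC1(C)CC(OC(=O)CN2CN(c3ccccc3)C3(CCN(C(=O)c4ccc(C5CCCCC5)cc4)CC3)C2=O)CC(C)(C)N1` gives 600 nM, and compound 3 `CC1(C)CC(OC(=O)CN2CN(c3ccccc3)C3(CCN(C(=O)c4ccc(C(C)(C)C)cc4)CC3)C2=O)CC(C)(C)N1` gives 1300 nM, which places compound 3 second highest of the three numbers. The steps show a 4.3-fold lower number from compound 1 to compound 2 (0.64 log units; beyond the scatter) and a 2.2-fold higher number from compound 2 to compound 3 (0.34 log units; beyond the scatter). Compound 4 `CC(C)(C)c1ccc(C(=O)N2CCC3(CC2)C(=O)N(CC(=O)N2CCCC(C(N)=O)C2)CN3c2ccccc2)cc1` differs from compound 3 at the carbonyl carbon: 3-carbamoylpiperidin-1-yl in place of (2,2,6,6-tetramethylpiperidin-4-yl)oxy on a carbonyl carbon. Within the data shown here, the step bearing on this is the one from compound 1 to compound 2, where a piperidinyl amide became the tetramethylpiperidinyloxy ester and the number fell; compound 4 reverses that ester back to a piperidinyl amide, so a modest rise in this assay is expected, a 2.3-fold higher number from compound 3 to compound 4 (0.36 log units; beyond the scatter). Compound 4 is therefore estimated at 3000 nM, within 1000 nM to 9000 nM.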

Compound 4, half-maximal inhibitory concentration: 16900 nM
Estimate against measurement, compound 4: 5.6-fold (0.75 log units) below; the whole stated range lies below it.
By their numbers in this assay, from the lowest: compound 2; then compounds 3 and 1 (each within the scatter of the next); then compound 4.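

In this assay, putting 3-carbamoylpiperidin-1-yl in place of (2,2,6,6-tetramethylpiperidin-4-yl)oxy on this carbonyl carbon gives (a 13-fold higher number from compound 3 to compound 4 (1.11 log units; beyond the scatter)), a large step. The earlier change at the same carbon was only modest (a 4.3-fold lower number from compound 1 to compound 2 (0.64 log units; beyond the scatter)), so this position can shift the number much further than compounds 1 to 3 showed. No measurement here explains the size of this step.

Still open, on these data alone, is whether the rise comes from the carbamoyl group or from losing the ester oxygen. A 3-carboxypiperidin-1-yl or unsubstituted piperidin-1-yl group at this carbon could help separate the two.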